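A Primary Amide Analogue of Two Weak Inhibitors

This account rests on a few compounds, and the source may have more. Where it says the series, first, only, none or still open, it means among the compounds named here.

Compound 1, `COC(=O)c1cccc(-c2cnc(C(O)CCc3ccc(-c4ccccc4)cc3)o2)n1`: 9000 nM in an assay for inhibition of Fatty-acid amide hydrolase 1 (Rattus norvegicus); a higher number here means a weaker inhibitor, a lower number a stronger inhibitor
Compound 2, `O=C(O)c1ccc(-c2cnc(C(O)CCc3ccc(-c4ccccc4)cc3)o2)nc1`: 10000 nM in this assay

For the measured compounds named here, compound 2 is one of only two measured compounds, and it sits beside compound 1 at a distance that is within the scatter: the single step known so far, a 1.1-fold higher number from compound 1 to compound 2 (0.05 log units; within the scatter), does not separate the two. Both are weak inhibitors.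

Compound 3, `NC(=O)c1cccc(-c2cnc(C(O)CCc3ccc(-c4ccccc4)cc3)o2)n1`, has not been measured. It differs from compound 2 in one place: 6-carbamoylpyridin-2-yl in place of 5-carboxypyridin-2-yl on an aromatic carbon. Going by the values given here, the only measured step bearing on this position exchanged one pyridyl group for another and stayed within the scatter, which gives no sign that changes at this end of the molecule move the numbers. Among the compounds with values here, no step with a carbamoyl group exists. The expected step is therefore none beyond the scatter, a 1.1-fold lower number from compound 2 to compound 3 (0.05 log units; within the scatter). Compound 3 is estimated at 9000 nM, with a range from 3000 nM to 27000 nM.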

Compound 3, inhibition constant: 20000 nM
Beside the measured number, compound 3's estimate is 2.2-fold (0.35 log units) below it, within the range that was stated.
By their numbers in this assay, from the lowest: compounds 1, 2 and 3 (each within the scatter of the next, the first and the last beyond it).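

For the compounds shown here, on the pyridine shared by compound 1 and compound 3, amino in place of methoxy on the carbonyl carbon gives a 2.2-fold higher number from compound 1 to compound 3 (0.35 log units; beyond the scatter) in this assay, the first step at this end of the molecule to pass the scatter, though only modestly. The other new step, a 2.0-fold higher number from compound 2 to compound 3 (0.30 log units; within the scatter), changes both the group and its place on the pyridine, yet it does not separate the two compounds. Nothing measured here explains either step.

Compound 2 and compound 3 leave open how much of their difference comes from the group and how much from its place, which a 6-carboxypyridin-2-yl group could help to separate. Also open, on these data alone, is how a nitrile or an N-methyl amide on the same pyridine would compare with the ester of compound 1.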